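The compounds below may be only part of what the source reports. "The series", "measured", "known", "first", "only" and "open" are said of these compounds alone.

Compounds measured so far:
compound 1 `N#Cc1ccc(Cn2cc(COc3ccc4c(=O)ccoc4c3)nn2)cc1`, > 100000 nM
compound 2 `O=c1ccoc2cc(OCc3cn(Cc4ccccc4Cl)nn3)ccc12`, 19700 nM
compound 3 `O=c1ccoc2cc(OCc3cn(Cc4ccc(Cl)cc4)nn3)ccc12`, 41700 nM

All three share one core and differ only in the group carried on the benzyl arm attached to the triazole. In a functional assay on QGY7701 cells (Homo sapiens) for cytotoxicity, read by MTT assay, with a stated time of 48 h (a lower number here means a stronger inhibitor, a higher number a weaker inhibitor), compound 1 gives only a limit, > 100000 nM, so its true number is not known. It sits at the limit of > 100000 nM in this assay, at which 1 of the 3 values shown sits, and is the weakest of the three by this reading. Compound 2 gives 19700 nM and compound 3 gives 41700 nM in this assay; the step of a 2.1-fold higher number from compound 2 to compound 3 (0.33 log units; beyond the scatter) is modest but beyond the scatter.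

Compound 4 `O=c1ccoc2cc(OCc3cn(Cc4ccccc4)nn3)ccc12` has not yet been measured. It differs from compound 1 by hydrogen in place of cyano on an aromatic carbon. Among the measured compounds shown here, two measured steps bear on this change, since both remove the cyano group: an at least 5.0-fold lower number from compound 1 to compound 2 (0.70 log units; beyond the scatter) and an at least 2.3-fold lower number from compound 1 to compound 3 (0.37 log units; beyond the scatter). Each replacement of the cyano gave a lower number, at least modestly, so removing it altogether is expected to do the same. The step to a plain phenyl is expected to resemble the step to compound 3 rather than the larger step to compound 2, so the expected step is an at least 2.2-fold lower number from compound 1 to compound 4 (0.34 log units; beyond the scatter). Compound 4 is therefore estimated at 45000 nM, with a range from 15000 nM to 100000 nM in this assay.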

Compound 4, half-maximal inhibitory concentration: > 100000 nM
Compound 4 was reported as a limit; the forecaster's own chance of this, stated with the estimate: 25%; middle value at least 2.2-fold (0.34 log units) from the limit.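

In this assay, taking the chloro group off the benzyl arm gives an at least 2.3-fold higher number from compound 3 to compound 4 (0.37 log units; beyond the scatter), and the same change from the other chlorinated compound gives an at least 5.0-fold higher number from compound 2 to compound 4 (0.70 log units; beyond the scatter). Compound 1 showed that a nitrile on this ring can go with no readable number, while compound 4 shows that removing the nitrile and leaving only hydrogen does not bring a readable number back, so among the four compounds shown, a readable number appears only with a chloro group on the ring. On these data alone, the step between the nitrile and hydrogen itself cannot be read, as each of the two compounds is reported only as a limit and the true numbers are unknown: the limit of > 100000 nM in this assay, at which 2 of the 4 values shown sit.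

As far as these compounds go, it therefore stays open whether the nitrile in compound 1 makes any difference compared with the plain benzyl arm of compound 4, in either direction. From the compounds shown here alone, it is also open whether a readable number is tied to chloro in particular, or would also appear with a fluoro, bromo, methyl or methoxy group on the same aromatic carbon.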